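Quinolinyl sulfone in place of trifluoromethylphenyl sulfone

A few compounds are considered here, and "the series" means these few. Any claim that something is new, unique, unknown or untested is made for them only; others in the source may bear on it.

Compound 1 `N#C/N=C(\NCc1ccc(S(=O)(=O)c2cccc(C(F)(F)F)c2)cc1)Nc1ccncc1` carries a cyanoguanidine linked through a benzylic sulfone to a 3-(trifluoromethyl)phenyl group. In an assay on isolated protein for inhibition of Nicotinamide phosphoribosyltransferase (Homo sapiens), read by mass spectrometry, with stated times of 15 min and 30 min (a lower number here means a stronger inhibitor, a higher number a weaker inhibitor), compound 1 gives 2.4 nM. Compound 2 `N#C/N=C(\NCc1ccc(S(=O)(=O)N2CC3CCC(C2)O3)cc1)Nc1cccnc1`, which has a bicyclic sulfonamide and a different pyridyl on the cyanoguanidine, gives in this assay a value of 4.4 nM. The two numbers lie within the usual scatter of each other, so neither compound can be placed above the other on these data.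

Compound 3 `N#C/N=C(\NCc1ccc(S(=O)(=O)c2cccc3cccnc23)cc1)Nc1ccncc1` keeps the whole of compound 1 except at one place: quinolin-8-yl in place of 3-(trifluoromethyl)phenyl on a sulfonyl sulfur. No measured pair among the compounds shown isolates this particular exchange, so the step it brings in this assay cannot be read from a neighbour. The change swaps one aryl sulfone for another of the same heavy-atom count, and the expectation is that the step from compound 1 to compound 3, a 1.7-fold higher number from compound 1 to compound 3 (0.22 log units; within the scatter), stays small, with no confident direction beyond the scatter. On that basis compound 3 is expected to give about 4 nM in this assay, with a likely range from 1 nM to 20 nM.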

Compound 3, half-maximal inhibitory concentration: 3.6 nM
Compound 3: the middle estimate sits 1.1-fold (0.05 log units) above what was measured; low and high end bracket the measured number.
By their numbers in this assay, from the lowest: compounds 1, 3 and 2 (each within the scatter of the next).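

In this assay, among the compounds shown here, the exchange of 3-(trifluoromethyl)phenyl for quinolin-8-yl on a sulfonyl sulfur gives the first step that can be read at this position (a 1.5-fold higher number from compound 1 to compound 3 (0.18 log units; within the scatter)). With the three fluorine atoms gone and a second six-membered aromatic ring in place, one with a hetero atom and a hydrogen-bond acceptor, the heavy-atom count is the same and the two compounds cannot be told apart in this assay. For this pair, then, the trifluoromethyl group is not needed to keep the number in the low range that compound 1 shows, and no measurement at hand bears on why the two aryl groups read alike.

What the compounds shown leave open is how much room this position has beyond these two groups of equal size, for instance with a plain phenyl, a smaller methyl, or a quinoline that carries a carboxylic acid. For the compounds shown here, they also leave open whether the same exchange reads alike when the pyridin-4-yl end of the cyanoguanidine is replaced by another ring, such as a pyrimidine or a plain phenyl, since every step so far rests on a single pair.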